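Compound 4: Pyridin-4-yl in Place of Ethyl

This account rests on a few compounds, and the source may have more. Where it says the series, first, only, none or still open, it means among the compounds named here.

Measured compounds:
compound 1 `CCN(Cc1cccs1)C(=O)COc1ccc(C)cc1` gives 8 nM
compound 2 `CCN(Cc1ccoc1)C(=O)COc1ccc(C)cc1` gives 136 nM
compound 3 `CCN(Cc1cccs1)C(=O)COc1ccc(C(C)C)cc1` gives 397 nM

These three values come from an assay on HEK293 cells for agonist activity at transient receptor potential cation channel subfamily M member 8 (Homo sapiens), read by fluorescence and calcium flux, with a stated time of 15 min; on this read-out lower numbers stand for an effect already at smaller amounts and higher numbers for an effect only at larger amounts of compound. Compound 1 stands lowest of the three; the nearest is a 17-fold higher number from compound 1 to compound 2 (1.23 log units; beyond the scatter) and the furthest is a 50-fold higher number from compound 1 to compound 3 (1.70 log units; beyond the scatter), both beyond the scatter. Compound 4 `Cc1ccc(OCC(=O)N(Cc2cccs2)c2ccncc2)cc1` has not yet been measured in this assay. It differs from compound 1 in one place: pyridin-4-yl in place of ethyl on an amide-type nitrogen.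

Neither measured step touches this place. The step to compound 2 alters the group on the saturated chain carbon bound to the amide-type nitrogen, and the step to compound 3 alters the group on the aromatic carbon; both were large and both raised the number. Among the measured compounds shown here, no measured step shows what a change directly on the amide-type nitrogen does. Given that every change from compound 1 seen so far raised the number by a large amount, and that the present change is larger in what it counts than either of those, a rise beyond the scatter is expected for compound 4, though its size is uncertain. The expected step is a 19-fold higher number from compound 1 to compound 4 (1.27 log units; beyond the scatter). Compound 4 is therefore estimated at 150 nM, within a range from 30 nM to 1000 nM.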

Compound 4, half-maximal effective concentration: 52 nM
For compound 4 the middle estimate is 2.9-fold (0.46 log units) above the measured one, within the range that was stated.
By their numbers in this assay, from the lowest: compound 1; then compound 4; then compound 2; then compound 3.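

In this assay, among the compounds shown here, the first reading at the amide-type nitrogen is a 6.5-fold higher number from compound 1 to compound 4 (0.81 log units; beyond the scatter), so this place responds to change, but the step counts as modest. Pyridin-4-yl brings 6 heavy atoms and a six-membered aromatic ring where ethyl has 2 heavy atoms and no ring, yet this exchange is classed below the two large steps seen elsewhere on compound 1, a 17-fold higher number from compound 1 to compound 2 (1.23 log units; beyond the scatter) and a 50-fold higher number from compound 1 to compound 3 (1.70 log units; beyond the scatter), although ethyl still gives the lower number of the pair. Nothing in the data shown accounts for the size of this step or says which feature of the entering group sets it.

The compounds shown leave open whether the ring nitrogen of pyridin-4-yl matters at all, a question that phenyl or pyridin-3-yl on the amide-type nitrogen would address, and whether methyl or a longer chain such as propyl would do better or worse than ethyl. Going by these compounds, it also remains open whether pyridin-4-yl gives a similar step when combined with furan-3-yl or isopropyl in the other two places.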